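A few compounds are considered here, and "the series" means these few. Any claim that something is new, unique, unknown or untested is made for them only; others in the source may bear on it.

Measured in a functional assay on PC-3 cells (Homo sapiens) for cytotoxicity, read by MTT assay, with a stated time of 72 h; a higher number here means a weaker inhibitor, a lower number a stronger inhibitor:
- compound 1 `COc1ccc(OC)c(/C=C/C(=O)Nc2cc3c(Nc4ccc(F)c(Cl)c4)ncnc3cc2OC)c1` gives 28600 nM
- compound 2 `COc1cc(/C=C/C(=O)Nc2cc3c(Nc4ccc(F)c(Cl)c4)ncnc3cc2O[C@H]2CCOC2)cc(OC)c1OC` gives 20500 nM

For the measured compounds named here, compound 2 lies within the usual scatter of compound 1, so these two values set no order between the compounds. Compound 3 `O=C(/C=C/c1ccccc1[N+](=O)[O-])Nc1cc2c(Nc3ccc(F)c(Cl)c3)ncnc2cc1O[C@H]1CCOC1` has yet to be measured in this assay. Its difference from compound 2 is 2-nitrophenyl in place of 3,4,5-trimethoxyphenyl on a double-bonded chain carbon bound to a double-bonded chain carbon, with 2-nitrophenyl in place of 3,4,5-trimethoxyphenyl on a double-bonded chain carbon bound to a double-bonded chain carbon. Going by the values given here, no measured pair differs in one place only, so the data give no direct guide to the size of this change. The expectation is therefore no step beyond the scatter in either direction, anchored on compound 2 at 20500 nM. The estimated change is a 1.1-fold lower number from compound 2 to compound 3 (0.06 log units; within the scatter). For compound 3 the estimated value is 18000 nM, with an expected range of 7000 nM to 45000 nM.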

Compound 3, half-maximal inhibitory concentration: 7760 nM
For compound 3 the middle estimate is 2.3-fold (0.37 log units) above the measured one; the measured number falls inside the stated range.
By their numbers in this assay, from the lowest: compound 3; then compounds 2 and 1 (each within the scatter of the next).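

In this assay, for the compounds shown here, the exchange of 3,4,5-trimethoxyphenyl for 2-nitrophenyl on a double-bonded chain carbon bound to a double-bonded chain carbon gives a 2.6-fold lower number from compound 2 to compound 3 (0.42 log units; beyond the scatter) and is the first single-place change to be read. The step is modest, but it shows that the number responds to the aryl group at this place, even though both groups hold one six-membered aromatic ring of carbon only and differ in heavy atoms and hydrogen-bond acceptors. No measurement shown here bears on what underlies the step.

As far as these compounds go, whether the step follows from the nitro group or from the loss of the three methoxy groups remains open, and an unsubstituted phenyl or a 2-aminophenyl at this place would help separate the two. Also open, from the compounds shown here alone, is whether the same exchange gives a similar step on the core of compound 1.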